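The source may hold more compounds than are shown below. What is called first, only, known or untested is meant among the compounds shown, and "the series" means these compounds.

Measured so far, in a functional assay on HEK293 cells for agonist activity at probable G-protein coupled receptor 27 (Homo sapiens), read by a luciferase reporter and beta-arrestin recruitment, with a stated time of 10 min; on this read-out lower numbers stand for an effect already at smaller amounts and higher numbers for an effect only at larger amounts of compound:
compound 1 `O=C(Nc1ccc(S(=O)(=O)Nc2ccccc2)cc1)c1cc(F)c(Cl)cc1F`: 141 nM
compound 2 `CN(c1ccccc1)S(=O)(=O)c1ccc(NC(=O)c2ccc(Cl)cc2Cl)cc1`: 2570 nM
compound 3 `O=C(Nc1ccc(S(=O)(=O)Nc2ccccc2)cc1)c1ccc(Br)cc1F`: 479 nM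

Compound 3 stands second highest of the three numbers; its nearest neighbour is compound 1 and its furthest compound 2. Compound 2 differs from compound 3 in two places at once, so its value is noted only as the highest number of the set.

Compound 4 `O=C(Nc1ccc(S(=O)(=O)Nc2ccccc2)cc1)c1ccc(Cl)cc1Br` has not been measured. It differs from compound 3 in one place: 2-bromo-4-chlorophenyl in place of 4-bromo-2-fluorophenyl on a carbonyl carbon.

Among the measured compounds shown here, the only single-place step on the same carbonyl carbon is a 3.4-fold higher number from compound 1 to compound 3 (0.53 log units; beyond the scatter), a modest change for a rearrangement of halogens on that ring. The change to compound 4 is again a rearrangement of halogens on the same ring, with no added donor or acceptor. A step of similar modest size is therefore expected, with the direction uncertain and leaning slightly toward a higher number; the expected step is a 1.3-fold higher number from compound 3 to compound 4 (0.10 log units; within the scatter).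

For compound 4 the estimate in this assay is 600 nM, within a range of 200 nM to 1800 nM.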

Compound 4, half-maximal effective concentration: 1020 nM
Estimate against measurement, compound 4: 1.7-fold (0.23 log units) below; the measured number falls inside the stated range.
By their numbers in this assay, from the lowest: compound 1; then compound 3; then compound 4; then compound 2.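

In this assay the exchange of 4-bromo-2-fluorophenyl for 2-bromo-4-chlorophenyl on the carbonyl carbon gives a 2.1-fold higher number from compound 3 to compound 4 (0.33 log units; beyond the scatter) even though the heavy-atom count stays the same and neither group has a hydrogen-bond donor, acceptor or net charge. Measured against the group in compound 1, 2-bromo-4-chlorophenyl gives a 7.2-fold higher number from compound 1 to compound 4 (0.86 log units; beyond the scatter) and is the largest step yet at this place. The three groups compared here therefore run in one order, from the lowest number: 4-chloro-2,5-difluorophenyl, 4-bromo-2-fluorophenyl, then 2-bromo-4-chlorophenyl.

Only halogens stand on this ring in the compounds shown, so what an amine, a carboxylic acid or a methoxy group would give at this carbonyl carbon remains open. Nothing at hand bears on what lies behind these steps.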